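The source may report more compounds than this note shows. Statements on the series, on what has been measured and on what is new or still open speak of the compounds shown alone.

Measured compounds in a functional assay on N2a cells (Mus musculus), with a stated time of 48 h, tested at 0.01 uM; on this read-out lower numbers stand for a weaker effect and higher numbers for a stronger effect at the one concentration tested:
- compound 1 `C#CC[C@@H]1C[C@H](n2cccc2C(C)=O)C(=O)O1` gives 8.03%
- compound 2 `C#CC[C@H]1C[C@H](n2cccc2C(C)=O)C(=O)O1` gives 9.04%
- compound 3 `C#CC[C@@H]1C[C@H](n2cccc2)C(=O)O1` gives 6.56%

Within the data shown here, all three numbers lie within the scatter of one another, so no compound can be set apart from the rest. Compound 2 stands next to compound 1, with the step of a number 1 percentage points higher from compound 1 to compound 2 (within the scatter); this pair differs only in configuration as drawn (the fact that compounds 1 and 2 differ only in the configuration as drawn). Compound 3 lacks the acetyl group of compound 1, and the step of a number 1.5 percentage points lower from compound 1 to compound 3 (within the scatter) shows that even removing the whole group leaves the read-out unmoved in this assay.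

Compound 4 `C#CC[C@H]1C[C@H](n2cccc2C(=O)CC)C(=O)O1` is not yet measured. It differs from compound 2 as follows: methyl in place of hydrogen on a saturated chain carbon bound to a carbonyl carbon. Among the measured compounds shown here, no measured step covers exactly this change. The nearest comparison is the step from compound 1 to compound 3, where hydrogen replaced the acetyl group and the read-out stayed within the scatter; a one-carbon extension of that same group is a smaller change than its removal. The expectation is therefore no step beyond the scatter from compound 2 to compound 4, estimated as a number 0 percentage points lower from compound 2 to compound 4 (within the scatter). For compound 4 the estimated value in this assay is 9%, expected to fall between 3% and 16%.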

Compound 4, a percentage reported as activity, at one concentration (the size of the read-out at that concentration, not a potency): 4.63%
The estimate for compound 4 lay 4.4 percentage points above the measured number; the measured number falls inside the stated range.
By their numbers in this assay, from the lowest: compounds 4, 3, 1 and 2 (each within the scatter of the next).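

In this assay, lengthening acetyl to propanoyl on the core of compound 2, with methyl in place of hydrogen on a saturated chain carbon bound to a carbonyl carbon, gives a number 4.4 percentage points lower from compound 2 to compound 4 (within the scatter). Among these compounds, the earlier steps covered only the removal of the whole acetyl group and a change in configuration as drawn, so this is the first reading on a larger group at this position, and it does not set propanoyl apart from acetyl on this read-out. Nothing shown gives a cause for this step.

Because the four values run from lowest to highest with each within the scatter of the next, the compounds shown leave open whether any change at this position can move the read-out beyond the scatter, and whether propanoyl behaves the same way in the configuration drawn for compound 1. Also open, on these data alone, is what a longer chain such as butanoyl, or a carboxylic acid or an amine at the end of this chain, would do at the one concentration tested.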